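Dibromo core series: aryl halide to nitrile step

The source may report more compounds than this note shows. Statements on the series, on what has been measured and on what is new or still open speak of the compounds shown alone.

Measured compounds:
compound 1 `O=C1CC(c2ccc(F)cc2)Nc2c(Br)cc(Br)cc21` — > 100000 nM
compound 2 `O=C1CC(c2ccc(Br)cc2)Nc2c(Br)cc(Br)cc21` — > 100000 nM

In a functional assay on MCF7 cells (Homo sapiens) for cytotoxicity, read by sulforhodamine B assay, with a stated time of 48 h (a lower number here means that less compound is tolerated, a higher number that more compound is tolerated), compound 1 gives only a limit of the assay, > 100000 nM, and no number. In this assay compound 2 likewise returns only a limit, > 100000 nM. Among the compounds with values here, both values therefore sit at the limit of > 100000 nM in this assay, at which 2 of the 2 values shown sit, and the one measured step, a step that the two limits leave unreadable from compound 1 to compound 2, cannot be read in size or direction; it says only that bromo in place of fluoro on an aromatic carbon kept the compound at the limit.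

Compound 3 `N#Cc1ccc(C2CC(=O)c3cc(Br)cc(Br)c3N2)cc1` is not yet measured. It differs from compound 2 by cyano in place of bromo on an aromatic carbon. Within the data shown here, no measured step covers cyano in place of bromo on an aromatic carbon, so the only guide is that both measured members sit at the limit.

Compound 3 is expected to show a number no higher from compound 2 to compound 3 (the limit leaves the size open), that is, no step beyond the scatter in this assay. The estimate for compound 3 in this assay is 100000 nM, expected between 30000 nM and 300000 nM, with a fair chance that only a limit is reported again.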

Compound 3, concentration lethal to 50% of the cells: > 100000 nM
Compound 3 ended at the assay's limit; the forecaster's own chance of this, stated with the estimate: 60%; the middle value lies on the limit itself.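

In this assay compound 3 gives > 100000 nM as a limit of the assay and not a number. The steps to compound 3 from compound 1 and from compound 2 cannot be read in size or direction. The compounds shown leave open whether any group on this aromatic carbon brings the series to a measurable lethal concentration.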